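Phenyl for Propyl at the Saturated Ring Carbon

A few compounds are considered here, and "the series" means these few. Any claim that something is new, unique, unknown or untested is made for them only; others in the source may bear on it.

Within the data shown here, compound 1 `CCCC1C(C(=O)OCc2ccccn2)=C(C)NC2=C1C(=O)CCC2` gives 2.6 in a physicochemical assay for lipophilicity, measured as octanol-water partition (on this read-out lower numbers stand for lower lipophilicity and higher numbers for higher lipophilicity), the highest of the three numbers measured so far. Among the measured compounds shown here, compound 3 `COc1cc(C2C(C(=O)OCc3ccccn3)=C(C)NC3=C2C(=O)CCC3)cc(OC)c1OC` gives 2.17 in this assay and compound 2 `COc1ccc(C2C(C(=O)OCc3cccnc3)=C(C)NC3=C2C(=O)CCC3)cc1` gives 1.54, both beyond the scatter below compound 1; neither differs from compound 1 in one place only, so their values show no single step. Compound 4 `CC1=C(C(=O)OCc2ccccn2)C(c2ccccc2)C2=C(CCCC2=O)N1` is not yet measured. It differs from compound 1 by phenyl in place of propyl on a saturated ring carbon. For the measured compounds named here, no measured pair isolates this change. A phenyl entering for a propyl is expected to raise this assay by a modest step, a number 0.20 log units higher from compound 1 to compound 4 (within the scatter), near the edge of the scatter; the lower numbers of compound 2 and compound 3 argue against a large rise. Compound 4 is therefore estimated at 2.8, within 2.3 to 3.3.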

Compound 4, partition coefficient: 2.72
For compound 4 the middle estimate is 0.08 log units above the measured one, within the range that was stated.
By their numbers in this assay, from the lowest: compound 2; then compound 3; then compounds 1 and 4 (each within the scatter of the next).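

At this saturated ring carbon, the series now has its first step in one place: in this assay, phenyl in place of propyl gives a number 0.12 log units higher from compound 1 to compound 4 (within the scatter) and stays within the scatter. Among these compounds, an aromatic ring of carbon can therefore take the place of this open chain with no resolved change on this read-out, which the earlier compounds, differing in more than one place, could not show. No available data explain this result.

Going by these compounds, what an amine, a carboxylic acid or a longer chain would give at this carbon in this assay remains open. Also open, on these data alone, is whether this change would read the same way on a core other than that of compound 1.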